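The compounds below may be only part of what the source reports. "The series", "measured", "known", "first", "only" and "open" are said of these compounds alone.

Of the compounds shown here, three that share one core have numbers so far in a functional assay on Ehrlich cells (Mus musculus) for cytotoxicity, read by LDH release, with a stated time of 48 h (a lower number here means a stronger inhibitor, a higher number a weaker inhibitor), for this series. Compound 1 `COc1ccc(C(=O)c2cc(C)ccc2OCC(=O)NNC(=O)c2cc3ccccc3oc2=O)cc1` gives 41200 nM in this test, compound 2 `Cc1ccc(OCC(=O)NNC(=O)c2cc3ccccc3oc2=O)c(C(=O)c2cccc(Cl)c2)c1` gives 65400 nM there, and compound 3 `Cc1ccc(OCC(=O)NNC(=O)c2cc3ccccc3oc2=O)c(C(=O)c2ccc(Cl)cc2)c1` gives 58000 nM there as well. Compound 3 cannot be told apart from the other two: the data show a 1.1-fold lower number from compound 2 to compound 3 (0.05 log units; within the scatter) and also a 1.4-fold higher number from compound 1 to compound 3 (0.15 log units; within the scatter) on this scale.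

Compound 4 `Cc1ccc(C(=O)c2cc(C)ccc2OCC(=O)NNC(=O)c2cc3ccccc3oc2=O)cc1` has not been measured yet. It departs from compound 3 in one place (methyl in place of chloro on an aromatic carbon) with methyl in place of chloro on an aromatic carbon, para to a large group, so that 4-chlorophenyl becomes 4-methylphenyl.

The closest measured change puts chloro in place of methoxy at that same spot and gives a 1.4-fold higher number from compound 1 to compound 3 (0.15 log units; within the scatter) in the test. Two further steps (a 1.6-fold higher number from compound 1 to compound 2 (0.20 log units; within the scatter) and a 1.1-fold lower number from compound 2 to compound 3 (0.05 log units; within the scatter)) change the same aryl group. Among the measured compounds shown here, all of them stay inside the usual scatter, but no measured compound yet carries methyl at this spot. No step beyond the scatter is therefore expected in this assay in either direction. The expected change is a 1.2-fold lower number from compound 3 to compound 4 (0.06 log units; within the scatter) and so stays small. For compound 4 the estimated value is 50000 nM within an expected range from 28000 nM to 90000 nM in this test.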

Compound 4, half-maximal inhibitory concentration: 81400 nM
Compound 4: the middle estimate sits 1.6-fold (0.21 log units) below what was measured; measured number inside the range.
By their numbers in this assay, from the lowest: compounds 1, 3, 2 and 4 (each within the scatter of the next).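

In this assay, among the compounds shown here, compound 4 puts a carbon substituent at this spot for the first time, as 4-methylphenyl in place of 4-chlorophenyl, and that swap gives a 1.4-fold higher number from compound 3 to compound 4 (0.15 log units; within the scatter). Set against the other two compounds, methyl in place of methoxy gives a 2.0-fold higher number from compound 1 to compound 4 (0.30 log units; within the scatter), and 4-methylphenyl in place of 3-chlorophenyl gives a 1.2-fold higher number from compound 2 to compound 4 (0.10 log units; within the scatter), so methyl joins methoxy and chloro as groups that cannot be told apart here, and every step in the set still lies within the scatter. Nothing available offers a reason for this flat picture.

On these data alone, what stays open is whether an amine, a carboxylic acid or a longer chain such as butyl on this same ring would give a step beyond the scatter in this assay. The four compounds also differ only in this one aryl group, so they leave open how the number would respond to a change elsewhere on the shared core, for instance replacing the methyl on the central ring with a methoxy group.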